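The source may report more compounds than this note shows. Statements on the series, on what has been measured and on what is new or still open speak of the compounds shown alone.

Series notes, plasma stability. The core of the series is shared across three measured compounds in an ADME assay on a cell-free system (plasma, Rattus norvegicus) for metabolic stability, read by LC-MS, with a stated time of 1 h, at 37 degrees C, tested at 100 uM; a higher number here means that more of the compound is left, a lower number that less of the compound is left: compound 1 `O=C(O)c1cc(-c2cccc(COc3ccc4c(c3)CN(C3CCCC3)C4=O)c2)ccc1O`, compound 2 `O=C(O)c1cc(-c2cccc(COc3ccc4c(=O)n(C5CC5)sc4c3)c2)ccc1Cl` and compound 3 `O=C(O)c1cc(-c2cccc(-c3ccc4c(c3)CN(C3CCCC3)C4=O)c2)ccc1Cl`. In this assay compound 1 gives 98%, compound 2 gives 100% and compound 3 gives 81%. Compound 1 thus stands second highest of the three numbers; the value of compound 2 lies within the usual scatter of it, so nothing separates the two, while compound 3 sits clearly lower, a gap beyond the scatter. Within the data shown here, no step between compounds differing in one place is available within the measured set, so no measured single-point step can be quoted.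

The next compound, compound 4 `O=C(O)c1cc(F)cc(-c2cccc(COc3ccc4c(c3)CN(C3CCCC3)C4=O)c2)c1`, differs from compound 1 as follows: 3-carboxy-5-fluorophenyl in place of 3-carboxy-4-hydroxyphenyl on an aromatic carbon. The rest of compound 1 is kept unchanged. Among the measured compounds shown here, with no measured step of this kind to lean on, and with two of the three measured compounds sitting near full recovery, the step of a number 3 percentage points lower from compound 1 to compound 4 (within the scatter) is expected to be none beyond the scatter. Compound 4 is therefore expected to return about 95% in this assay, within a range of 82% to 100%.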

Compound 4, percent of the compound remaining: 95%
Compound 4: the middle estimate sits on the measured number at the digits printed; measured number inside the range.
By their numbers in this assay, from the lowest: compound 3; then compounds 4, 1 and 2 (each within the scatter of the next).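

Among these compounds, a step of a number 3 percentage points lower from compound 1 to compound 4 (within the scatter) in this assay is the first single-place comparison available, and it shows that 3-carboxy-5-fluorophenyl can take the place of 3-carboxy-4-hydroxyphenyl on this aromatic carbon, meta to a large group, without a change that the read-out can separate from the usual scatter. The exchange goes from 2 hydrogen-bond donors to 1 and brings in a fluorine while the rest of compound 1 stays the same, so in these two compounds neither the hydroxy group nor the fluorine has a resolved effect on the percent of compound remaining. No accompanying measurement bears on this result, which therefore stands as an observation without an explanation.

As far as these compounds go, whether the same exchange would behave alike on the core of compound 2 or compound 3 stays open, as this single step covers one core only. Also open is how this ring would fare with a methyl ester or a primary amine in place of the groups shown here, since every compound so far carries a free carboxylic acid at this ring.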